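Shortening the Alkyne Chain on the Shared Core

The source may report more compounds than this note shows. Statements on the series, on what has been measured and on what is new or still open speak of the compounds shown alone.

This study compares a small family of compounds built on one shared core, which differ only in the group attached to a saturated ring carbon. The measure used throughout is a functional assay on KB cells (Homo sapiens), read by MTT assay; a higher number here means a weaker inhibitor, a lower number a stronger inhibitor. Compound 1 `C#C[C@]1(O)[C@@H](CO)O[C@@H](n2ccc(=O)[nH]c2=O)[C@@H]1O` carries an ethynyl group. In this assay compound 1 gives > 350000 nM; 29 nM (2 entries). Compound 2 `C=C[C@@]1(O)[C@@H](CO)O[C@@H](n2ccc(=O)[nH]c2=O)[C@@H]1O` carries a vinyl group, and in this assay compound 2 gives 51800 nM. Compound 3 `CCC#C[C@@]1(O)[C@@H](CO)O[C@@H](n2ccc(=O)[nH]c2=O)[C@@H]1O` carries a but-1-yn-1-yl group; in this assay compound 3 gives 226000 nM, the higher of the two plain numbers known here, reached by a 4.4-fold higher number from compound 2 to compound 3 (0.64 log units; beyond the scatter).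

Compound 4 `CC#C[C@@]1(O)[C@@H](CO)O[C@@H](n2ccc(=O)[nH]c2=O)[C@@H]1O` differs from compound 3 by hydrogen in place of methyl on a saturated chain carbon bound to a triple-bonded carbon. Among the compounds with values here, the one measured step, from compound 2 to compound 3, moved toward a higher number as the attached group grew; the change to compound 4 goes the other way, toward a smaller group, so a modest move toward a lower number is expected, though compound 1 shows how uncertain such readings can be. Compound 4 is therefore estimated at 110000 nM, within a range of 30000 nM to 400000 nM. The expected step is a 2.1-fold lower number from compound 3 to compound 4 (0.31 log units; beyond the scatter).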

Compound 4, half-maximal inhibitory concentration: 70800 nM
The estimate for compound 4 lay 1.6-fold (0.19 log units) above the measured number; the range from low to high includes it.
By their numbers in this assay, from the lowest: compounds 2 and 4 (each within the scatter of the next); then compound 3.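

Trimming the but-1-yn-1-yl group to prop-1-yn-1-yl, with hydrogen replacing methyl on a saturated chain carbon bound to a triple-bonded carbon, gives in this assay a 3.2-fold lower number from compound 3 to compound 4 (0.50 log units; beyond the scatter), so a change this small at the end of the chain is enough to shift the reading beyond the usual scatter. The earlier step, a 4.4-fold higher number from compound 2 to compound 3 (0.64 log units; beyond the scatter), changed the kind of bond and the chain length together, whereas the new comparison separates the two: a 1.4-fold higher number from compound 2 to compound 4 (0.14 log units; within the scatter), and this lies within the scatter, so vinyl and prop-1-yn-1-yl cannot be told apart here. Among compounds 2, 3 and 4, then, the triple bond alone does not go with a higher number, since compound 4 keeps it and stays within the scatter of compound 2, while the higher number appears only with the added methyl of compound 3.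

From the compounds shown here alone, whether a longer chain such as pent-1-yn-1-yl, or an amine on the same saturated ring carbon, would move the number further remains open. The place of compound 1, the ethynyl member, is also unsettled, since one of its two widely separated entries is a limit of the assay rather than a number: the several entries of compound 1 in this assay, > 350000 nM; 29 nM (2 entries)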